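A few compounds are considered here, and "the series" means these few. Any claim that something is new, unique, unknown or untested is made for them only; others in the source may bear on it.

Measured in a functional assay on SK-OV-3 cells (Homo sapiens) for antiproliferative activity, read by MTT assay, with a stated time of 24 h; a higher number here means a weaker inhibitor, a lower number a stronger inhibitor:
Compound 1 `COc1ccc(/C=C/C(=O)c2ccc(OC)c3c2OC(C)(C)C=C3)c(F)c1`: 4880 nM
Compound 2 `COc1ccc(C(=O)/C=C/c2ccccc2)c2c1C=CC(C)(C)O2`: > 10000 nM

Compound 2 stands at the limit of > 10000 nM in this assay, at which 1 of the 2 values shown sits. That figure is a limit and not a number.

Compound 3 `COc1ccc(/C=C/C(=O)c2ccc(OC)c3c2OC(C)(C)C=C3)cn1` has 6-methoxypyridin-3-yl in place of the phenyl of compound 2, on a double-bonded chain carbon bound to a double-bonded chain carbon: 6-methoxypyridin-3-yl in place of phenyl on a double-bonded chain carbon bound to a double-bonded chain carbon.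

Going by the values given here, one measured step bears on this place: an at least 2.0-fold higher number from compound 1 to compound 2 (0.31 log units; beyond the scatter), with phenyl replacing 2-fluoro-4-methoxyphenyl. That step is beyond the scatter, though its size is known only as a bound. Among the compounds with values here, the group entering compound 3 is not the one in compound 1, but both are methoxy-bearing aromatic rings, so the earlier step serves as a rough guide, read in reverse. A modest move toward a lower number is therefore expected, and a result that stays at the limit remains possible. The expected change is an at least 1.6-fold lower number from compound 2 to compound 3 (0.22 log units; that floor lies within the scatter). Compound 3 is estimated at 6000 nM, with an expected range from 2500 nM to 13000 nM.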

Compound 3, half-maximal inhibitory concentration: > 10000 nM
Compound 3 gave a limit, no number; the forecaster's own chance of this, stated with the estimate: 30%; middle value at least 1.6-fold (0.22 log units) away from the limit.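

Compound 3 gives > 10000 nM in this assay, which is a limit of the assay and not a number. A methoxy-bearing aromatic ring at this place is therefore not enough on its own to give a measurable value, as 6-methoxypyridin-3-yl in place of 2-fluoro-4-methoxyphenyl gives an at least 2.0-fold higher number from compound 1 to compound 3 (0.31 log units; beyond the scatter). The step between compound 2 and compound 3 cannot be read, and among these three compounds only compound 1, with its 2-fluoro-4-methoxyphenyl, gives a number rather than a limit: the limit of > 10000 nM in this assay, at which 2 of the 3 values shown sit.

The compounds shown do not separate the contributions of the fluoro group, the methoxy group and the ring nitrogen to the difference between compound 1 and compound 3. As far as these compounds go, whether 4-methoxyphenyl, 2-fluorophenyl or a ring carrying a dimethylamino group at this place would give a number in this assay remains open, as does how far compound 2 and compound 3 differ from each other.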